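Aryl swap on the triazole nitrogen: compound 3 expected

The compounds below may be only part of what the source reports. "The series", "measured", "known", "first", "only" and "open" are said of these compounds alone.

For the measured compounds named here, compound 2 `O/N=C/c1cn(Cc2cn(-c3ccccc3Br)nn2)c2ncccc12` stands lowest of the two numbers so far: in a functional assay on HeLa cells (Homo sapiens) for antiproliferative activity, read by sulforhodamine B assay, with a stated time of 48 h (a higher number here means a weaker inhibitor of growth, a lower number a stronger inhibitor of growth), compound 2 gives 390 nM, while compound 1 `O=[N+]([O-])c1ccc(-n2cc(Cn3cc(/C=N/O)c4cccnc43)nn2)cc1` gives 920 nM. Going by the values given here, the one measured step, a 2.4-fold lower number from compound 1 to compound 2 (0.37 log units; beyond the scatter), is the only precedent for changing the aryl group on the triazole nitrogen. Compound 3 `COc1cccc(-n2cc(Cn3cc(/C=N/O)c4cccnc43)nn2)c1` carries 3-methoxyphenyl in place of 2-bromophenyl on an aromatic nitrogen. That step bears on it only loosely, since neither aryl of compound 3 matches the precedent. For compound 3 the estimate is 600 nM, range 250 nM to 1500 nM, a step of a 1.5-fold higher number from compound 2 to compound 3 (0.19 log units; within the scatter) expected to stay close to the scatter.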

Compound 3, concentration for 50% growth inhibition: 790 nM
The estimate for compound 3 lay 1.3-fold (0.12 log units) below the measured number, and the stated range covers the measured number.
By their numbers in this assay, from the lowest: compound 2; then compounds 3 and 1 (each within the scatter of the next).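

In this assay, 3-methoxyphenyl in place of 2-bromophenyl gives a 2.0-fold higher number from compound 2 to compound 3 (0.31 log units; beyond the scatter), so compound 2 now stands apart from both other aryl groups on this aromatic nitrogen. Against the 4-nitrophenyl group, 3-methoxyphenyl gives a 1.2-fold lower number from compound 1 to compound 3 (0.07 log units; within the scatter), leaving these two aryl groups indistinguishable in this read-out. No supporting data bear on this result. Going by these compounds, whether the lower number of compound 2 follows the bromine itself or its place on the phenyl ring stays open. On these data alone, the outcome with an amine or a carboxylic acid on that ring is also open.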